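Removing the Methylsulfonyl Group From a Bcl-2 Acylsulfonamide

The source may report more compounds than this note shows. Statements on the series, on what has been measured and on what is new or still open speak of the compounds shown alone.

Compound 2 `CN(C)CC[C@H](CSc1ccccc1)Nc1ccc(S(=O)(=O)NC(=O)c2ccc(N3CCN(Cc4ccccc4-c4ccc(Cl)cc4)CC3)cc2)cc1S(C)(=O)=O` belongs to a small set of acylsulfonamides tested in an assay on isolated protein for displacement of a labelled ligand from Apoptosis regulator Bcl-2 (Homo sapiens), read by fluorescence polarization; on this read-out lower numbers stand for stronger inhibition and higher numbers for weaker inhibition. In this assay compound 2 gives < 1 nM, which is a limit of the assay rather than a number. Its close relative compound 1 `CN(C)CC[C@H](CSc1ccccc1)Nc1ccc(S(=O)(=O)NC(=O)c2ccc(N3CCN(Cc4ccccc4-c4ccc(Cl)cc4)CC3)cc2)cc1C(F)(F)F` carries trifluoromethyl where compound 2 carries methylsulfonyl, and in this assay compound 1 gives < 1 nM, again a limit. The step that the two limits leave unreadable from compound 1 to compound 2 cannot be sized because the limit of < 1 nM in this assay, at which 2 of the 2 values shown sit, hides whatever difference there may be between the two substituents.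

Compound 3 `CN(C)CC[C@H](CSc1ccccc1)Nc1ccc(S(=O)(=O)NC(=O)c2ccc(N3CCN(Cc4ccccc4-c4ccc(Cl)cc4)CC3)cc2)cc1` has not yet been measured. It differs from compound 2 by hydrogen in place of methylsulfonyl on an aromatic carbon. No measured step covers this change: the one step shown, from trifluoromethyl to methylsulfonyl, exchanges one group for another and says nothing about removing the group altogether. With both neighbours sitting at the limit, one nevertheless expects compound 3 to rise above it, the step of an at least 20-fold higher number from compound 2 to compound 3 (1.30 log units; beyond the scatter) being estimated to weaken binding beyond the usual scatter. Compound 3 is estimated at 20 nM, in the range 2 nM to 200 nM.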

Compound 3, inhibition constant: < 1 nM
Compound 3 gave a limit, no number (the forecaster's own chance of this, stated with the estimate: 15%); middle value at least 20-fold (1.30 log units) from the limit.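

In this assay compound 3 gives < 1 nM, which is a limit of the assay and not a number. No step among compound 1, compound 2 and compound 3 can be read, because all three stop at the same point: the limit of < 1 nM in this assay, at which 3 of the 3 values shown sit.

The compounds shown leave open whether trifluoromethyl, methylsulfonyl and hydrogen on this aromatic carbon differ at all in this read-out, and by how much.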